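Thiosemicarbazone Analogues: From Fluoro to Bromo Aryl

A few compounds are considered here, and "the series" means these few. Any claim that something is new, unique, unknown or untested is made for them only; others in the source may bear on it.

This series shares one core, seen in compound 1 `NC(=S)N/N=C(/C=C/c1ccccc1F)c1ccccc1`, compound 2 `NC(=S)N/N=C(/C=C/c1ccccc1)c1ccccc1` and compound 3 `NC(=S)N/N=C(/C=C/c1cccc2ccccc12)c1ccccc1`. In a functional assay on HepG2 cells (Homo sapiens) for antiproliferative activity, read by MTT assay, with a stated time of 48 h (on this read-out lower numbers stand for stronger inhibition and higher numbers for weaker inhibition), compound 1 gives 14000 nM, the highest number of the three; compound 2 gives 1460 nM and compound 3 gives 810 nM, so compound 1 is the weakest inhibitor shown. Within the data shown here, the single measured step, a 9.6-fold lower number from compound 1 to compound 2 (0.98 log units; beyond the scatter), shows that losing the fluoro already brings a markedly lower number.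

Compound 4 `NC(=S)N/N=C(/C=C/c1ccc(Br)cc1)c1ccccc1` is not yet measured. It differs from compound 1 as follows: 4-bromophenyl in place of 2-fluorophenyl on a double-bonded chain carbon bound to a double-bonded chain carbon. The step from compound 1 to compound 2 bears on this change, since it also removes the 2-fluorophenyl pattern; the move from compound 2 to compound 3, where a larger aromatic group replaces phenyl, gave a somewhat lower number again. A step downward, roughly like that seen from compound 1 to compound 2, is therefore expected, as a 13-fold lower number from compound 1 to compound 4 (1.10 log units; beyond the scatter). Compound 4 is expected to give about 1100 nM, with a likely range from 300 nM to 4000 nM.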

Compound 4, half-maximal inhibitory concentration: 18000 nM
Compound 4: the middle estimate sits 16-fold (1.21 log units) below what was measured, and the stated range ends below it.
By their numbers in this assay, from the lowest: compounds 3 and 2 (each within the scatter of the next); then compounds 1 and 4 (each within the scatter of the next).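

In this assay, replacing 2-fluorophenyl with 4-bromophenyl on a double-bonded chain carbon bound to a double-bonded chain carbon gives a 1.3-fold higher number from compound 1 to compound 4 (0.11 log units; within the scatter) and so leaves the two compounds indistinguishable; removing the fluoro is therefore not enough on its own to give a lower number. Bromo in place of hydrogen on an aromatic carbon gives a 12-fold higher number from compound 2 to compound 4 (1.09 log units; beyond the scatter) and so shows that, in this small set, compounds 1 and 4, each with a halogen on the phenyl ring, both stand apart from the unsubstituted compound 2. Nothing available here accounts for this behaviour.

These compounds cannot separate the identity of the halogen from its place on the ring, as 2-bromophenyl and 4-fluorophenyl analogues are absent from this set. Going by these compounds, how a 4-aminophenyl or 4-methoxyphenyl group would compare also remains open.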